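The source may hold more compounds than are shown below. What is called first, only, known or untested is meant among the compounds shown, and "the series" means these compounds.

Compound 3 `O=C1/C(=C\c2cccc(Oc3ccccc3)c2)c2ccccc2N1c1c(Cl)cccc1Cl` carries a phenoxy group and in a functional assay on MIA PaCa-2 cells (Homo sapiens) for cytotoxicity, read by MTT assay, with a stated time of 72 h (a higher number here means that more compound is needed for the effect, a lower number that less compound is needed), gives only a limit, > 100 ug/mL, rather than a number. Compound 3 therefore stands at the limit of > 100 ug/mL in this assay, at which 1 of the 3 values shown sits. The two companions in the set, compound 1 `O=C1/C(=C\c2cc3ccccc3nc2Cl)c2ccccc2N1c1c(Cl)cccc1Cl` at 5 ug/mL and compound 2 `O=C1/C(=C\c2ccc(F)cc2)c2ccccc2N1c1c(Cl)cccc1Cl` at 5 ug/mL, both return measured values. Compound 4 `O=C1/C(=C\c2cccc(Br)c2)c2ccccc2N1c1c(Cl)cccc1Cl` differs from compound 3 in one place: bromo in place of phenoxy on an aromatic carbon. Among the compounds with values here, no measured pair shows this exact exchange, so the expectation leans on compound 2, whose value is 5 ug/mL. A large fall in the amount needed, from the limit toward the measured companions, is expected, namely an at least 12-fold lower number from compound 3 to compound 4 (1.09 log units; beyond the scatter). Compound 4 is estimated at 8 ug/mL, within a range from 3 ug/mL to 40 ug/mL.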

Compound 4, concentration for half-maximal effect: 5 ug/mL
For compound 4 the middle estimate is 1.6-fold (0.20 log units) above the measured one; measured number inside the range.
By their numbers in this assay, from the lowest: compounds 1, 2 and 4 (each within the scatter of the next). At a limit, above all of these: compound 3.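

In this assay, compound 3 alone stands at a limit rather than a number: the limit of > 100 ug/mL in this assay, at which 1 of the 4 values shown sits. Within the data shown here, at this aromatic carbon, meta to a large group, bromo in place of phenoxy gives an at least 20-fold lower number from compound 3 to compound 4 (1.30 log units; beyond the scatter), the first sign that the group at this position can decide the result. Bromo at this position also matches the 4-fluorophenyl compound, with no change at the digits printed from compound 2 to compound 4 (within the scatter).

The compounds shown leave open whether the ring of phenoxy or its oxygen matters, and whether a methoxy group or an amine at this carbon would read like bromo or like phenoxy.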